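The compounds below may be only part of what the source reports. "The series", "measured", "known", "first", "only" and "open" are said of these compounds alone.

Among the compounds with values here, in an ADME assay on Vero cells (Chlorocebus sabaeus) for cytotoxicity, read by trypan blue exclusion, with a stated time of 24 h (on this read-out higher numbers stand for weaker inhibition and lower numbers for stronger inhibition), compound 1 (`COc1cc(C[C@@H](C)[C@@H](C)Cc2ccc(OC(C)=O)c(OC)c2)ccc1O`) gives 112 ug/mL, the highest of the three numbers so far. Compound 2 (`COc1cc(C[C@@H](C)[C@@H](C)Cc2ccc(OC(=O)c3cnccn3)c(OC)c2)ccc1O`) gives 43.3 ug/mL. Compound 3 (`COc1cc(C[C@@H](C)[C@@H](C)Cc2ccc(OC(=O)c3cccnc3)c(OC)c2)ccc1OC(=O)c1cccnc1`) gives 36.3 ug/mL, also lower than compound 1, but it differs from compound 1 in more than one place and offers no clean comparison.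

The step under consideration leads from compound 1 to compound 4 (`COc1cc(C[C@@H](C)[C@@H](C)Cc2ccc(OC(=O)c3ccc(Br)cc3)c(OC)c2)ccc1O`), with 4-bromophenyl in place of methyl on a carbonyl carbon. Within the data shown here, the one measured step bearing on it is a 2.6-fold lower number from compound 1 to compound 2 (0.41 log units; beyond the scatter), with pyrazin-2-yl in place of methyl on a carbonyl carbon, and it is modest in size. Among the measured compounds shown here, no measured compound carries a 4-bromophenyl, so this precedent is a single and imperfect guide. For the measured compounds named here, with compound 2 at 43.3 ug/mL as the only single-place comparison, a modest step toward a lower number is expected in this assay, with a wide margin on either side. The expected change is a 2.5-fold lower number from compound 1 to compound 4 (0.40 log units; beyond the scatter). Compound 4 is estimated at 45 ug/mL, with an expected range of 20 ug/mL to 100 ug/mL.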

Compound 4, half-maximal inhibitory concentration: 112 ug/mL
Compound 4: middle estimate off by 2.5-fold (0.40 log units), on the low side; the measured number lies above the stated range.
By their numbers in this assay, from the lowest: compounds 3 and 2 (each within the scatter of the next); then compounds 1 and 4 (each within the scatter of the next).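

In this assay the change from acetoxy to ((4-bromophenyl)carbonyl)oxy gives no change at the digits printed from compound 1 to compound 4 (within the scatter) in this series, so placing an aromatic ring on this carbonyl carbon does not by itself lower the number. The two ring-bearing replacements also separate, with a 2.6-fold higher number from compound 2 to compound 4 (0.41 log units; beyond the scatter) on exchanging pyrazin-2-yl for 4-bromophenyl, so the lower number seen with pyrazin-2-yl does not extend to every aromatic ring at this place. No measurement at hand accounts for this separation between the two rings.

From the compounds shown here alone, with only these two rings at this place, it remains open whether the lower number belongs to pyrazin-2-yl alone or would also appear with other rings, and an unsubstituted phenyl on the same carbonyl carbon would show whether the bromine matters to the comparison. Also open, going by these compounds, is how non-aromatic replacements for methyl at this position would read in this assay on the core of compound 1, for instance a longer alkyl chain or a chain ending in an amine.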